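Swapping the hydrazone aryl group on a shared core

This account rests on a few compounds, and the source may have more. Where it says the series, first, only, none or still open, it means among the compounds named here.

compound 1 `CCCSc1nc(N/N=C/c2ccccc2Cl)c2nnn(Cc3ccccc3)c2n1`: 13800 nM
compound 2 `C#CCSc1nc(N/N=C/c2c(O)ccc3ccccc23)c2nnn(Cc3ccccc3)c2n1`: 8970 nM

In a functional assay on MCF7 cells (Homo sapiens) for antiproliferative activity, read by MTT assay, with a stated time of 72 h (on this read-out higher numbers stand for weaker inhibition and lower numbers for stronger inhibition), compound 1 gives the higher of the two numbers, and compound 2 gives a number that lies within the scatter of it, so no order between them is claimed. Compound 3 `CCCSc1nc(N/N=C(\C)c2ccccc2O)c2nnn(Cc3ccccc3)c2n1` differs from compound 1 by a group of 10 heavy atoms (8 carbon, 1 nitrogen, 1 oxygen; one six-membered aromatic ring of carbon only) in place of a group of 9 heavy atoms (7 carbon, 1 nitrogen, 1 chlorine; one six-membered aromatic ring of carbon only), on a nitrogen on an aromatic ring. For the measured compounds named here, no measured pair covers this change, so compound 3 is expected to land close to compound 1, with a step of a 1.3-fold lower number from compound 1 to compound 3 (0.10 log units; within the scatter) expected to stay within the scatter. Compound 3 is therefore estimated at 11000 nM, in the range 3500 nM to 35000 nM.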

Compound 3, half-maximal inhibitory concentration: 11000 nM
Compound 3: the middle estimate sits on the measured number at the digits printed; measured number inside the range.
By their numbers in this assay, from the lowest: compounds 2, 3 and 1 (each within the scatter of the next).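

In this assay, for the compounds shown here, the step of a 1.3-fold lower number from compound 1 to compound 3 (0.10 log units; within the scatter) is the first reading of a change in one place on the shared core. On a nitrogen on an aromatic ring, the group of 10 heavy atoms, with its hydrogen-bond donor, stands in for the chlorine-bearing group of 9 heavy atoms without the number leaving the scatter. Nothing available bears on why this is so. The compounds shown leave open whether a group carrying an amine or a carboxylic acid at this same place would give a number beyond the scatter of compound 1.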